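Azetidin-1-yl in place of piperidin-1-yl on the shared core

A few compounds are considered here, and "the series" means these few. Any claim that something is new, unique, unknown or untested is made for them only; others in the source may bear on it.

In a functional assay on ECa-109 cells for inhibition, with ECa-109 cell line (Homo sapiens) as the target, read by sulforhodamine B assay (a lower number here means a stronger inhibitor, a higher number a weaker inhibitor), compound 1 `O=C1C(Nc2ccc(Br)cc2)=CC(=O)c2c1nc1n2[C@H]2OC[C@@H](O)[C@H]2OC1` gives 1980 nM and compound 2 `Cc1ccc(NC2=CC(=O)c3c(nc4n3[C@H]3OC[C@@H](O)[C@H]3OC4)C2=O)cc1C` gives 4090 nM.

Compound 3 `O=C1C(N2CCCCC2)=CC(=O)c2c1nc1n2[C@H]2OC[C@@H](O)[C@H]2OC1` gives > 8000 nM as a limit and no number; its place is the limit of > 8000 nM in this assay, at which 1 of the 3 values shown sits.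

Compound 4 `O=C1C(N2CCC2)=CC(=O)c2c1nc1n2[C@H]2OC[C@@H](O)[C@H]2OC1` differs from it by azetidin-1-yl in place of piperidin-1-yl on a double-bonded ring carbon on a double-bonded ring carbon.

Two measured steps reach the piperidin-1-yl group: an at least 4.0-fold higher number from compound 1 to compound 3 (0.60 log units; beyond the scatter) lies beyond the scatter, while an at least 1.9-fold higher number from compound 2 to compound 3 (0.29 log units; that floor lies within the scatter) has a floor within it. Neither compares saturated rings of different size, so they bear on this change only indirectly.

No step beyond the scatter is expected, the estimated step being a step that the limit leaves unreadable from compound 3 to compound 4 in this assay here.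

For compound 4 the expected value is 9000 nM with an estimated range of 4000 nM to 20000 nM in this assay here.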

Compound 4, half-maximal inhibitory concentration: > 16000 nM
Compound 4: no number, only a limit (the forecaster's own chance of this, stated with the estimate: 55%); middle value at least 1.7-fold (0.24 log units) from the limit.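

In this assay compound 4 gives only a limit, and compound 3 does too, so the step between the two saturated rings cannot be read. On the double-bonded ring carbon, azetidin-1-yl gives an at least 3.9-fold higher number from compound 2 to compound 4 (0.59 log units; beyond the scatter) and an at least 8.0-fold higher number from compound 1 to compound 4 (0.90 log units; beyond the scatter). A four-membered ring here therefore joins the six-membered ring in giving no number, and both stay apart from the two arylamino compounds.

Still open, on these data alone, is whether cyclohexylamino, a saturated ring that keeps the amine hydrogen, would give a number at this carbon, which would separate the aromatic ring from that hydrogen.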